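Thiophen-2-yl for 4-methylphenyl: expected cytotoxicity

The source may hold more compounds than are shown below. What is called first, only, known or untested is meant among the compounds shown, and "the series" means these compounds.

Measured compounds:
- Compound 1 `O=C(/C=C/c1ccc2c(c1)B(O)OC2)c1ccc(C(F)(F)F)cc1`: in an ADME assay on L929 cells (Mus musculus) for cytotoxicity, read by resazurin assay, with a stated time of 72 h (a higher number here means a weaker inhibitor, a lower number a stronger inhibitor), compound 1 gives > 10 ug/mL, which is a limit of the assay rather than a number.
- Compound 2 `Cc1ccc(C(=O)/C=C/c2ccc3c(c2)B(O)OC3)cc1`: in this assay compound 2 gives > 10 ug/mL, again a limit.
- Compound 3 `COc1ccc(C(=O)/C=C/c2ccc3c(c2)B(O)OC3)cc1`: in this assay compound 3 gives > 10 ug/mL, also a limit.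

Compound 2 therefore stands at the same limit as every other value shown (the limit of > 10 ug/mL in this assay, at which 3 of the 3 values shown sit). The steps among the three, a step that the two limits leave unreadable from compound 1 to compound 2, a step that the two limits leave unreadable from compound 1 to compound 3 and a step that the two limits leave unreadable from compound 2 to compound 3, cannot be read because both ends sit at the limit.

Compound 4 `O=C(/C=C/c1ccc2c(c1)B(O)OC2)c1cccs1` differs from compound 2 at the carbonyl carbon: thiophen-2-yl in place of 4-methylphenyl on a carbonyl carbon. Among the compounds with values here, none of the measured steps touches this part of the molecule; they all vary the group on the aromatic carbon of the phenyl ring, and all three are unreadable, so none bears directly on the change to compound 4. With every measured compound at the limit, no step beyond the scatter can be inferred in this assay, in either direction.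

Compound 4 is therefore expected to give about 15 ug/mL, in a range from 5 ug/mL to 50 ug/mL, most probably reported again as a limit. The expected step is a step that the limit leaves unreadable from compound 2 to compound 4.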

Compound 4, half-maximal inhibitory concentration: > 10 ug/mL
Compound 4 was reported as a limit; the forecaster's own chance of this, stated with the estimate: 70%; the middle value lies beyond the limit too.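

In this assay compound 4 gives > 10 ug/mL, which is a limit of the assay. Compound 2 sits at that same limit, so no step can be read for thiophen-2-yl in place of 4-methylphenyl: the limit of > 10 ug/mL in this assay, at which 4 of the 4 values shown sit. The compounds shown leave open the actual cytotoxic strength of all four, as none has a number.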